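A few compounds are considered here, and "the series" means these few. Any claim that something is new, unique, unknown or untested is made for them only; others in the source may bear on it.

Going by the values given here, compound 1 `Fc1ccc(-c2ccc(Cn3ccnc3)cc2)cn1` gives 4% in an assay for inhibition of steroid 17-alpha-hydroxylase/17,20 lyase (Homo sapiens), using NADPH, tested at 0.2 uM (a higher number here means a stronger effect of the compound at the concentration tested, a lower number a weaker effect), the lower of the two numbers measured so far. Compound 2 `CCC(c1ccc(-c2ccsc2)cc1)n1ccnc1` gives 28% in this assay, a result that lies beyond the scatter above compound 1. Among the compounds with values here, no two measured compounds differ in only one place, so no measured step is available to guide the next change. Compound 3 `ClCc1ccc(-c2ccc(Cn3ccnc3)cc2)cn1` differs from compound 1 by chloromethyl in place of fluoro on an aromatic carbon. The expected step of a number 6 percentage points higher from compound 1 to compound 3 (within the scatter) is small and is not expected to exceed the scatter of the measurement. For compound 3 the estimate is 10%, within 0% to 30%.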

Compound 3, a percentage reported as inhibition, at one concentration (the size of the read-out at that concentration, not a potency): 9%
For compound 3 the middle estimate is 1 percentage points above the measured one; the measured number falls inside the stated range.
By their numbers in this assay, from the lowest: compounds 1 and 3 (each within the scatter of the next); then compound 2.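

At this position, next to the ring nitrogen and para to a large group, chloromethyl in place of fluoro gives a number 5 percentage points higher from compound 1 to compound 3 (within the scatter) in this assay. This first single-place comparison in the series therefore separates neither group from the other, even though chloromethyl brings 2 heavy atoms where fluoro has 1. No available evidence bears on this result.

On these data alone, whether an amine, a carboxylic acid or a longer chain at this position would give a step beyond the scatter remains open.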